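This account rests on a few compounds, and the source may have more. Where it says the series, first, only, none or still open, it means among the compounds named here.

Measured so far:
compound 1 `C#CCN(C)Cc1cccc(NC(=O)CCCCCCC(=O)NO)c1` gives 420 nM in a functional assay on DU-145 cells (Homo sapiens) for inhibition, read by MTT assay, with a stated time of 48 h; a higher number here means a weaker inhibitor of growth, a lower number a stronger inhibitor of growth
compound 2 `C#CCN(C)Cc1cccc(NC(=O)CCCCCCCC(=O)NO)c1` gives 3780 nM in this assay
compound 3 `C#CCN(C)Cc1ccc(NC(=O)CCCCCCCC(=O)NO)cc1` gives 3400 nM in this assay

Compound 2 differs from compound 1 by (hydroxycarbamoyl)methyl in place of hydroxycarbamoyl on a saturated chain carbon, six bonds along the chain from a carbonyl carbon, which gave a 9.0-fold higher number from compound 1 to compound 2 (0.95 log units; beyond the scatter). Compound 3 and compound 2 lie within the scatter of each other; the difference between the core of compound 3 and that of compound 1 is not broken down here.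

Compound 4 `C#CCN(C)Cc1ccc(NC(=O)CCCCCCCCC(=O)NO)cc1` is not yet measured. It differs from compound 3 by (hydroxycarbamoyl)methyl in place of hydroxycarbamoyl on a saturated chain carbon, seven bonds along the chain from a carbonyl carbon. The place is not the same as in the earlier step: six bonds along the chain from a carbonyl carbon there, seven bonds here, so this is the same kind of change, not the same change. The expectation rests on a single measured example on a different core and is therefore loose. In this assay the step from compound 3 to compound 4 is expected to be a 2.6-fold higher number from compound 3 to compound 4 (0.42 log units; beyond the scatter), taken as smaller than a 9.0-fold higher number from compound 1 to compound 2 (0.95 log units; beyond the scatter) given the different place. Compound 4 is estimated at 9000 nM, with a likely range from 3000 nM to 35000 nM.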

Compound 4, concentration for 50% growth inhibition: 2740 nM
Compound 4: middle estimate off by 3.3-fold (0.52 log units), on the high side; the measured number lies below the stated range.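

With the core of compound 3, replacing hydroxycarbamoyl with (hydroxycarbamoyl)methyl gives a 1.2-fold lower number from compound 3 to compound 4 (0.09 log units; within the scatter) in this assay. This change therefore does not carry over with a constant size from one core to the other: the same change on two cores in this assay, a 9.0-fold higher number (0.95 log units; beyond the scatter) from compound 1 to compound 2 and a 1.2-fold lower number (0.09 log units; within the scatter) from compound 3 to compound 4, 11-fold (1.05 log units) apart, beyond the scatter of two such steps

For the compounds shown here, this does not show that the core alone sets the difference: the place also differs, six bonds along the chain from a carbonyl carbon in one step and seven bonds in the other, and each core supplies only one step. The compounds shown leave open how the change behaves at the same place on both cores. They also leave open whether a longer chain, or a carboxylic acid in place of hydroxycarbamoyl, would fit either trend.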